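The source may report more compounds than this note shows. Statements on the series, on what has been measured and on what is new or still open speak of the compounds shown alone.

Three compounds share one core and differ only in the group hanging from it. Compound 1 `CC(C)(C)c1ccc(Oc2ccc3c(NCCCNCc4ccco4)ccnc3c2)cc1`, compound 2 `Fc1ccc(-c2ccc3c(NCCCNCc4ccco4)ccnc3c2)cc1` and compound 3 `COc1cccc(Oc2ccc3c(NCCCNCc4ccco4)ccnc3c2)c1` were all tested in a physicochemical assay for solubility, with a stated time of 18 h, at pH 7.4; on this read-out higher numbers stand for higher solubility and lower numbers for lower solubility. In this assay compound 1 gives 14500 nM, compound 2 gives 32000 nM, and compound 3 gives 14500 nM. Compound 3 therefore stands level with compound 1, the two together at the lower end of the three numbers, while compound 2 sits higher, the gap being a 2.2-fold lower number from compound 2 to compound 3 (0.34 log units; beyond the scatter) when read from compound 2 to compound 3.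

Compound 4 `CN(C)c1cccc(Oc2ccc3c(NCCCNCc4ccco4)ccnc3c2)c1` is the next step. It differs from compound 3 by dimethylamino in place of methoxy on an aromatic carbon.

The two measured steps touch the same region of the molecule but not this exact exchange. Swapping the whole aryl group on the oxygen gave no change at the digits printed from compound 1 to compound 3 (within the scatter), and replacing a fluorophenyl with a methoxyphenoxy gave a 2.2-fold lower number from compound 2 to compound 3 (0.34 log units; beyond the scatter). Neither involved trading one small group for another on the outer ring, so the guidance is indirect. Since the closest comparison shows no change, the expected step in this assay from compound 3 to compound 4 is a 1.1-fold higher number from compound 3 to compound 4 (0.04 log units; within the scatter), not beyond the scatter. Compound 4 is expected to give 16000 nM, within a range from 7000 nM to 36000 nM.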

Compound 4, solubility: 14500 nM
For compound 4 the middle estimate is 1.1-fold (0.04 log units) above the measured one, and the stated range covers the measured number.
By their numbers in this assay, from the lowest: compounds 1, 3 and 4 (each within the scatter of the next); then compound 2.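

Methoxy and dimethylamino are the first pair of small groups to be exchanged at this place on the outer ring, and in this assay the exchange gives no change at the digits printed from compound 3 to compound 4 (within the scatter) even though the entering group brings a nitrogen in place of an oxygen and one more heavy atom. The wider comparisons keep the same picture: there is no change at the digits printed from compound 1 to compound 4 (within the scatter) when the whole 4-(tert-butyl)phenyl is replaced by 3-(dimethylamino)phenyl, while a 2.2-fold lower number from compound 2 to compound 4 (0.34 log units; beyond the scatter) is the modest gap that separates compound 4 from the directly attached 4-fluorophenyl group. Nothing measured here explains why the number holds steady across this exchange.

Both groups compared at this place carry no net charge and no hydrogen-bond donor, so the compounds shown say nothing about how a primary amine or a carboxylic acid would behave there. On these data alone, whether dimethylamino would give the same number on a different carbon of the outer ring, or on a ring attached directly to the shared core as in compound 2, also remains open.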